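Thiophene to furan in compound 3: an expected cytotoxicity step

The source may report more compounds than this note shows. Statements on the series, on what has been measured and on what is new or still open speak of the compounds shown alone.

Three compounds were measured in an ADME assay on NIH3T3 cells (Homo sapiens) for cytotoxicity, read by sulforhodamine B assay, with a stated time of 48 h; a lower number here means a stronger inhibitor, a higher number a weaker inhibitor:
- compound 1 `CC(=O)OC[C@H]1O[C@@H](n2cc(CN3C(=O)/C(=C/c4ccccc4)c4ccccc43)nn2)[C@H](OC(C)=O)[C@@H](OC(C)=O)[C@@H]1OC(C)=O` gives > 100000 nM, which is a limit of the assay and not a number
- compound 2 `CC(=O)OC[C@H]1O[C@@H](n2cc(CN3C(=O)/C(=C/C=C/c4ccccc4)c4ccccc43)nn2)[C@H](OC(C)=O)[C@@H](OC(C)=O)[C@@H]1OC(C)=O` gives 12300 nM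
- compound 3 `CC(=O)OC[C@H]1O[C@@H](n2cc(CN3C(=O)/C(=C/c4cccs4)c4ccccc43)nn2)[C@H](OC(C)=O)[C@@H](OC(C)=O)[C@@H]1OC(C)=O` gives 48100 nM

All three share one core and differ only in the group on a double-bonded chain carbon bound to a double-bonded ring carbon. Compound 3 has the highest number of the two compounds that gave a number; its nearest neighbour is compound 2, and the step of a 3.9-fold higher number from compound 2 to compound 3 (0.59 log units; beyond the scatter) lies beyond the scatter. The step of an at least 2.0-fold lower number from compound 1 to compound 3 (0.31 log units; beyond the scatter) is only a lower bound, because compound 1 sits at the limit of > 100000 nM in this assay, at which 1 of the 3 values shown sits.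

Compound 4 `CC(=O)OC[C@H]1O[C@@H](n2cc(CN3C(=O)/C(=C/c4ccco4)c4ccccc43)nn2)[C@H](OC(C)=O)[C@@H](OC(C)=O)[C@@H]1OC(C)=O` is not yet measured. It differs from compound 3 by furan-2-yl in place of thiophen-2-yl on a double-bonded chain carbon bound to a double-bonded ring carbon. Among the measured compounds shown here, no measured step swaps one five-membered aromatic ring for another; the steps that bear on it, an at least 2.0-fold lower number from compound 1 to compound 3 (0.31 log units; beyond the scatter) and a 3.9-fold higher number from compound 2 to compound 3 (0.59 log units; beyond the scatter), show that this position does shift the number, but all of them involve six-membered or chain groups. With so little to go on, the expected step of a 1.1-fold higher number from compound 3 to compound 4 (0.06 log units; within the scatter) in this assay is small and may stay within the scatter. Compound 4 is estimated at 55000 nM, with a range from 20000 nM to 150000 nM.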

Compound 4, half-maximal inhibitory concentration: 31800 nM
Compound 4: middle estimate off by 1.7-fold (0.24 log units), on the high side, within the range that was stated.
By their numbers in this assay, from the lowest: compound 2; then compounds 4 and 3 (each within the scatter of the next). At a limit, above all of these: compound 1.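

Exchanging one five-membered aromatic ring for another, with oxygen as the hetero atom in place of sulfur, gives a 1.5-fold lower number from compound 3 to compound 4 (0.18 log units; within the scatter) in this assay, so on a double-bonded chain carbon bound to a double-bonded ring carbon this change does not separate the two compounds. Compound 2, with its 2-phenylethenyl group, stays apart from the furan-2-yl compound as well, with a 2.6-fold higher number from compound 2 to compound 4 (0.41 log units; beyond the scatter), so the gap seen earlier between 2-phenylethenyl and thiophen-2-yl is not particular to the sulfur ring. The step of an at least 3.1-fold lower number from compound 1 to compound 4 (0.49 log units; beyond the scatter) is only a lower bound, since compound 1 gives a limit of the assay and not a number: the limit of > 100000 nM in this assay, at which 1 of the 4 values shown sits.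

Going by these compounds, it remains open whether a 2-(furan-2-yl)ethenyl or 2-(thiophen-2-yl)ethenyl group would give a number close to that of compound 2, which would help show whether the longer chain or the phenyl ring at its end matters more. Also open, on these data alone, is how a pyrrol-2-yl ring, with nitrogen as its hetero atom, or a furan-2-yl ring carrying an amine or a carboxylic acid would behave at this place.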